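Extending the side chain of a cyclobutyl prostaglandin analogue

A few compounds are considered here, and "the series" means these few. Any claim that something is new, unique, unknown or untested is made for them only; others in the source may bear on it.

Measured so far:
compound 1, `CCCC1([C@@H](O)C/C=C/C2[C@H](O)CC(=O)[C@@H]2CCc2ccc(C(=O)O)cc2)CCC1`, > 10000 nM
compound 2, `CCC1([C@@H](O)C/C=C/[C@H]2[C@H](O)CC(=O)[C@@H]2C/C=C\CCCC(=O)O)CCC1`, > 10000 nM

Compound 1 has the structure `CCCC1([C@@H](O)C/C=C/C2[C@H](O)CC(=O)[C@@H]2CCc2ccc(C(=O)O)cc2)CCC1`. In an assay on CHO cells for binding affinity to prostaglandin E2 receptor EP4 subtype (Mus musculus) (on this read-out lower numbers stand for stronger inhibition and higher numbers for weaker inhibition), compound 1 reaches only a limit, > 10000 nM. Compound 2 has the structure `CCC1([C@@H](O)C/C=C/[C@H]2[C@H](O)CC(=O)[C@@H]2C/C=C\CCCC(=O)O)CCC1`. In this assay compound 2 likewise gives only a limit, > 10000 nM, and not a number. Both values sit at the same place, the limit described by the limit of > 10000 nM in this assay, at which 2 of the 2 values shown sit, so compound 2 stands where every value shown stands: at the edge of what the assay can report, with no measurable affinity.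

Compound 3, `CCCCCC1([C@@H](O)C/C=C/[C@H]2[C@H](O)CC(=O)[C@@H]2C/C=C\CCCC(=O)O)CCC1`, has not been measured. It differs from compound 2 in one place: propyl in place of hydrogen on a saturated chain carbon, two bonds along the chain from a saturated ring carbon. Going by the values given here, no pair of measured compounds shows what such a step does in this assay, so no direction can be read from the numbers. The expectation is therefore that compound 3 stays near the limit, with a modest possibility of measurable affinity; the estimated step from compound 2 to compound 3 is an at least 2.0-fold lower number from compound 2 to compound 3 (0.30 log units; that floor lies within the scatter). Compound 3 is estimated at 5000 nM, within a range from 500 nM to 20000 nM.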

Compound 3, inhibition constant: 2100 nM
Beside the measured number, compound 3's estimate is 2.4-fold (0.38 log units) above it; the range from low to high includes it.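

In this assay, going from 1-ethylcyclobutyl to 1-pentylcyclobutyl gives an at least 4.7-fold lower number from compound 2 to compound 3 (0.67 log units; beyond the scatter), which shows that this position is sensitive to the length of the chain it carries. The propyl that enters holds only carbon, with no hydrogen-bond donors or acceptors and no net charge, so extending a plain saturated chain at this place is enough to bring a compound off the limit and give a real number. The step can only be stated as a minimum, and its true size remains unknown, because the value of compound 2 is a limit and not a number: the limit of > 10000 nM in this assay, at which 2 of the 3 values shown sit.

The compounds shown do not tell whether affinity would keep improving with a longer chain than pentyl, level off or fall again, and a single step cannot separate the effect of chain length from that of any other feature of the added carbons. As far as these compounds go, it also remains open whether a branched chain, a hydroxyl group or an amine at the end of the chain would be tolerated at this place, or whether the same extension would help on the side chain of compound 1.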